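Shifting the trifluoromethyl group on the pendant phenyl ring

The compounds below may be only part of what the source reports. "The series", "measured", "known", "first", "only" and "open" are said of these compounds alone.

Among the compounds with values here, compound 3 `COc1ccc(-n2nc(Sc3ccc(Cl)cc3)cc(CC[C@@H](C)NC(=O)[C@H]3CNCC[C@@H]3c3ccc(C(F)(F)F)cc3)c2=O)cc1` stands second highest among the three numbers so far in an assay on CHO cells for binding affinity to Melanocortin receptor 4 (Homo sapiens); a lower number here means a stronger inhibitor, a higher number a weaker inhibitor; compound 3 gives 3.8 nM. Its nearest neighbour is compound 1 `COc1ccc(-n2nc(Sc3ccc(Cl)cc3)cc(CC[C@@H](C)NC(=O)[C@H]3CNCC[C@@H]3c3ccc(Cl)cc3)c2=O)cc1`, for which compound 1 gives 2.4 nM; the step between them, a 1.6-fold higher number from compound 1 to compound 3 (0.20 log units; within the scatter), sits within the scatter. Its furthest neighbour is compound 2 `COc1ccc(-n2nc(Sc3ccc(Cl)cc3)cc(CC[C@@H](C)NC(=O)[C@H]3CNCC[C@@H]3c3cccc(F)c3)c2=O)cc1`, for which compound 2 gives 490 nM; here a 130-fold lower number from compound 2 to compound 3 (2.11 log units; beyond the scatter) is a large step.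

Compound 4 `COc1ccc(-n2nc(Sc3ccc(Cl)cc3)cc(CC[C@@H](C)NC(=O)[C@H]3CNCC[C@@H]3c3cccc(C(F)(F)F)c3)c2=O)cc1` has not yet been measured. It differs from compound 3 in one place: 3-(trifluoromethyl)phenyl in place of 4-(trifluoromethyl)phenyl on a saturated ring carbon. Within the data shown here, two measured steps bear on this change, both involving the same saturated ring carbon: a 200-fold higher number from compound 1 to compound 2 (2.31 log units; beyond the scatter) and a 130-fold lower number from compound 2 to compound 3 (2.11 log units; beyond the scatter). In both, the 3-fluorophenyl compound stands far weaker than the 4-chlorophenyl and 4-(trifluoromethyl)phenyl compounds. No 3-(trifluoromethyl)phenyl analogue has been measured, so the size of the step for compound 4 carries real uncertainty. Compound 4 is nonetheless expected to show a large step toward weaker binding, a 66-fold higher number from compound 3 to compound 4 (1.82 log units; beyond the scatter). Compound 4 is estimated at 250 nM, with a range from 40 nM to 1500 nM.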

Compound 4, half-maximal inhibitory concentration: 100 nM
For compound 4 the middle estimate is 2.5-fold (0.40 log units) above the measured one; measured number inside the range.
By their numbers in this assay, from the lowest: compounds 1 and 3 (each within the scatter of the next); then compound 4; then compound 2.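

Moving the trifluoromethyl group alone, with the atoms of the substituent unchanged, is enough to weaken binding substantially in this assay (a 26-fold higher number from compound 3 to compound 4 (1.42 log units; beyond the scatter)), so the placement on the phenyl ring matters independently of the group's identity, something compound 2 could not show while it differed from compound 3 in both group and placement. Within the data shown here, the 3-(trifluoromethyl)phenyl group also falls well short of the 4-chlorophenyl group (a 42-fold higher number from compound 1 to compound 4 (1.62 log units; beyond the scatter)), and across these four compounds, both compounds with a 3-substituted phenyl ring are clearly weaker than both with a 4-substituted one, with no compound going against this. The group at that placement still counts, though less, since trifluoromethyl improves on fluoro (a 4.9-fold lower number from compound 2 to compound 4 (0.69 log units; beyond the scatter)), and compound 4 therefore sits apart from compound 2 while remaining far from compounds 1 and 3.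

Nothing presented here accounts for why the placement has such a large effect. From the compounds shown here alone, it remains open whether a nitrile, a methoxy group or a plain unsubstituted phenyl group would fit the same order, and whether the gap between placements holds for chloro as it does across these compounds.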